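The source may hold more compounds than are shown below. What is called first, only, known or untested is meant among the compounds shown, and "the series" means these compounds.

Among the three compounds measured in an ADME assay on microsomes from liver (Homo sapiens) for metabolic stability, with a stated time of 10 min (on this read-out lower numbers stand for a less stable compound and higher numbers for a more stable compound), compound 3 `CCS(=O)(=O)NC(=O)c1ccc(Nc2nc(NC3(c4ccc(Cl)cc4)CC3)nc(OCC(F)(F)F)n2)cc1` gives 100% and stands level with compound 1 `O=C(NS(=O)(=O)c1ccc(F)cc1)c1ccc(Nc2nc(NC3(c4ccc(Cl)cc4)CC3)nc(OCC(F)(F)F)n2)cc1`, which gives 100%; together these two are the highest of the three numbers. Compound 2 `CC(C)(C)NC(=O)NCCS(=O)(=O)NC(=O)c1ccc(Nc2nc(NC3(c4ccc(Cl)cc4)CC3)nc(OCC(F)(F)F)n2)cc1` gives 96%. All the steps between them are small: no change at the digits printed from compound 1 to compound 3 (within the scatter), a number 4 percentage points lower from compound 1 to compound 2 (within the scatter) and a number 4 percentage points higher from compound 2 to compound 3 (within the scatter). Compound 4 `CC(=O)NCCS(=O)(=O)NC(=O)c1ccc(Nc2nc(NC3(c4ccc(Cl)cc4)CC3)nc(OCC(F)(F)F)n2)cc1` differs from compound 3 by acetamido in place of hydrogen on a saturated chain carbon, two bonds along the chain from a sulfonyl sulfur. Among the compounds with values here, the step that bears on this change is the one in which another group occupied that same place, and it gave only a number 4 percentage points higher from compound 2 to compound 3 (within the scatter), so no step beyond the scatter is expected in this assay. Compound 4 is therefore expected to give 96%, with a range from 85% to 100%. The expected step is a number 4 percentage points lower from compound 3 to compound 4 (within the scatter).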

Compound 4, percent of the compound remaining: 95%
Compound 4: the middle estimate sits 1 percentage points above what was measured; low and high end bracket the measured number.
By their numbers in this assay, from the lowest: compounds 4, 2, 1 and 3 (each within the scatter of the next).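

In this assay, acetamido on this chain carbon stays within the scatter (a number 5 percentage points lower from compound 3 to compound 4 (within the scatter)), so a second, smaller group at this place also leaves the read-out unmoved. Exchanging the end of that chain gives only a small step (a number 1 percentage points lower from compound 2 to compound 4 (within the scatter)), and 2-acetamidoethyl in place of 4-fluorophenyl on the sulfonyl sulfur gives a step that also lies within the scatter (a number 5 percentage points lower from compound 1 to compound 4 (within the scatter)). No supporting measurement offers a reason for this. Still open, as far as these compounds go, is whether an amine or a carboxylic acid at this place, or a longer chain carrying acetamido, would stay within the scatter too.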